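Amino in place of chloro on a shared core

A few compounds are considered here, and "the series" means these few. Any claim that something is new, unique, unknown or untested is made for them only; others in the source may bear on it.

Of the compounds shown here, three have been measured in a functional assay on K562 cells (Homo sapiens) for cytotoxicity, read by sulforhodamine B assay, with a stated time of 48 h; on this read-out lower numbers stand for stronger inhibition of growth and higher numbers for weaker inhibition of growth. Compound 1 `ClCc1ccc(Cn2cnc3c(Cl)ncnc32)cc1` gives 2910 nM, compound 3 `ClCc1cccc(Cn2cnc3c(Cl)nc(Cl)nc32)c1` gives 1580 nM, and compound 2 `ClCc1ccccc1Cn1cnc2c(Cl)nc(Cl)nc21` gives 150 nM, the lowest of the three numbers and beyond the scatter from each of the other two. Compound 4 `Nc1nc(Cl)c2ncn(Cc3ccccc3CCl)c2n1` has not yet been measured. It differs from compound 2 in one place: amino in place of chloro on an aromatic carbon. Within the data shown here, no measured pair shows this exchange, so nothing here tells how large its effect is. The expected step in this assay is a modest weakening, a 2.7-fold higher number from compound 2 to compound 4 (0.43 log units; beyond the scatter). Compound 4 is estimated at 400 nM, with a likely range from 120 nM to 1500 nM.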

Compound 4, concentration for 50% growth inhibition: 4470 nM
Compound 4: the middle estimate sits 11-fold (1.05 log units) below what was measured, and the stated range ends below it.
By their numbers in this assay, from the lowest: compound 2; then compounds 3, 1 and 4 (each within the scatter of the next, the first and the last beyond it).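

In this assay, putting amino in place of chloro on the aromatic carbon between two ring nitrogen atoms gives a 30-fold higher number from compound 2 to compound 4 (1.47 log units; beyond the scatter), a large step. Among these compounds, this is the first measured exchange at this position, and it shows that growth inhibition depends strongly on which group sits there. No measurement available here explains why the step is so large. From the compounds shown here alone, whether a methoxy or a methylamino group at this carbon would keep compound 2's inhibition remains open. Also open, going by these compounds, is whether the same exchange would cost as much in compound 3.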